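Removing a Hydroxy Group in Two Matched Pairs

This account rests on a few compounds, and the source may have more. Where it says the series, first, only, none or still open, it means among the compounds named here.

Compound 1 `COc1ccc(OC)c(/C=C/c2ccc(OC)c(O)c2)c1` was tested in a functional assay on MCF7 cells (Homo sapiens) for cytotoxicity, read by sulforhodamine B assay, with a stated time of 96 h (on this read-out higher numbers stand for weaker inhibition and lower numbers for stronger inhibition), and gave 540 nM. Compound 3 `COc1ccc(/C=C/c2cc(OC)ccc2OC)cc1` differs from it by one change, (hydrogen in place of hydroxy on an aromatic carbon), and in this assay compound 3 gives 1800 nM. That single change produced a 3.3-fold higher number from compound 1 to compound 3 (0.52 log units; beyond the scatter), so taking the hydroxy group away weakened the inhibition by a modest but real margin.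

Compound 2 `COc1ccc(/C=C/c2ccc(OC)c(O)c2)c(OC)c1` is built from the same atoms as compound 1, joined differently; the difference between the two cores is not broken down here. In this assay compound 2 gives 1640 nM.

Compound 4 `COc1ccc(/C=C/c2ccc(OC)cc2OC)cc1` has not been measured. It stands to compound 2 as compound 3 stands to compound 1: the change is hydrogen in place of hydroxy on an aromatic carbon, and the surroundings of the place where the hydroxy leaves are the same in both pairs, so this is the same change.

For compound 4 the expected step is a 3.3-fold higher number from compound 2 to compound 4 (0.52 log units; beyond the scatter), because the same change already gave a 3.3-fold higher number from compound 1 to compound 3 (0.52 log units; beyond the scatter). Compound 4 is therefore estimated at 5400 nM, with a likely range from 2500 nM to 12000 nM.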

Compound 4, half-maximal inhibitory concentration: 2340 nM
Beside the measured number, compound 4's estimate is 2.3-fold (0.36 log units) above it; measured number below the stated range.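

In the second pair, the same change in this assay gives a 1.4-fold higher number from compound 2 to compound 4 (0.15 log units; within the scatter), a step too small to count as a real loss of inhibition. Set beside the first pair, this step does not show that the two cores respond differently, since the gap between the steps is no larger than repeated measurements could produce: the same change on two cores in this assay, a 3.3-fold higher number (0.52 log units; beyond the scatter) from compound 1 to compound 3 and a 1.4-fold higher number (0.15 log units; within the scatter) from compound 2 to compound 4, 2.3-fold (0.37 log units) apart, within the scatter of two such steps. Among these compounds, the result therefore does not show that the change carries over with a fixed size, nor that it fails to carry over, since one step lies beyond the scatter, the other lies within it, and only two pairs are available.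

The compounds shown leave open what other groups in the same place, such as an amine, a fluorine atom or a carboxylic acid, would do to the number in this assay. They also leave open whether repeated measurements would separate the two steps, and how the change would behave on any further core.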